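The source may report more compounds than this note shows. Statements on the series, on what has been measured and on what is new or still open speak of the compounds shown alone.

Measured in an ADME assay on HepG2 cells (Homo sapiens) for inhibition, read by luminescence and CellTiter-Glo, with stated times of 24 h and 48 h; on this read-out lower numbers stand for stronger inhibition and higher numbers for weaker inhibition:

- compound 1 `Cc1ccc(C(=O)N(CC(=O)NCc2ccccc2)Cc2ccc(C(=O)NO)cc2)c(C)c1`: 3710 nM
- compound 2 `CC(C)c1ccc(C(=O)N(Cc2ccc(C(=O)NO)cc2)C(C)(C)C(=O)NC2CCCCC2)cc1`: > 50000 nM
- compound 3 `Cc1ccc(C(=O)N(CC(=O)NC2CCCCC2)Cc2ccc(C(=O)NO)cc2)c(C)c1`: 8330 nM

Compound 2 stands at > 50000 nM, which is a limit of this assay and not a number. Compound 4 `CC(C)c1ccc(C(=O)N(Cc2ccc(C(=O)NO)cc2)C(C)(C)C(=O)NCc2ccccc2)cc1` has not yet been measured. It differs from compound 2 by one change: benzyl in place of cyclohexyl on an amide-type nitrogen. This puts benzyl in place of cyclohexyl on an amide-type nitrogen.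

Among the compounds with values here, one measured step bears on this change, and it runs the opposite way. Going from benzyl to cyclohexyl gives a 2.2-fold higher number from compound 1 to compound 3 (0.35 log units; beyond the scatter). Those two compounds differ from compound 2 elsewhere in their structures, so the comparison is only a guide. Read in reverse, this modest step suggests a modestly lower number, meaning somewhat stronger inhibition. From the compounds shown here alone, the starting point is unknown, so compound 4 could also end up at the limit. The expected change is an at least 1.4-fold lower number from compound 2 to compound 4 (0.15 log units; that floor lies within the scatter). Compound 4 is estimated at 35000 nM, with an expected range of 12000 nM to 70000 nM.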

Compound 4, half-maximal inhibitory concentration: > 50000 nM
Compound 4: a limit, no number (the forecaster's own chance of this, stated with the estimate: 35%); at least 1.4-fold (0.15 log units) between middle value and limit.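

Compound 2 and compound 4 both give a limit rather than a number, so the step from cyclohexyl to benzyl between them cannot be read: the limit of > 50000 nM in this assay, at which 2 of the 4 values shown sit. Left open is how strongly either compound inhibits, and whether this change matters in these two compounds.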